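The compounds below may be only part of what the source reports. "The series", "measured", "known", "first", "only" and "open" are said of these compounds alone.

Series notes. For the measured compounds named here, in an assay on isolated protein for inhibition of DNA topoisomerase 1 (Homo sapiens), with a stated time of 30 min, tested at 100 uM (a lower number here means a weaker effect, a higher number a stronger effect of the compound at the concentration tested), compound 1 `Oc1ccc(-c2cc(-c3cccnc3)nc(-c3ccccc3Cl)c2)cc1` gives 0.9%, the lowest of the two numbers measured so far. Going by the values given here, compound 2 `Oc1ccc(-c2cc(-c3cccnc3)nc(-c3cccc(Cl)c3)c2)cc1` gives 55.2% in this assay; the step of a number 54.3 percentage points higher from compound 1 to compound 2 (beyond the scatter) is the only measured step here, and it concerns the chlorophenyl group, not the pyridyl group.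

Compound 3 `Oc1ccc(-c2cc(-c3ccncc3)nc(-c3ccccc3Cl)c2)cc1` is not yet measured in this assay. It differs from compound 1 as follows: pyridin-4-yl in place of pyridin-3-yl on an aromatic carbon. Among the compounds with values here, no measured step in this assay touches the pyridyl group, so the step from compound 1 to compound 2 gives no direct guidance for this change; it shows only that a single positional change can move the read-out in this assay a long way. With compound 1 at 0.9%, a drop is hardly possible, and the default expectation is a step of a number 7.1 percentage points higher from compound 1 to compound 3 (within the scatter), not beyond the scatter, with a wide upper range. The estimated value for compound 3 in this assay is 8%, expected between 0% and 40%.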

Compound 3, a percentage reported as inhibition, at one concentration (the size of the read-out at that concentration, not a potency): 9.9%
Compound 3: middle estimate off by 1.9 percentage points, on the low side; low and high end bracket the measured number.
By their numbers in this assay, from the lowest: compounds 1 and 3 (each within the scatter of the next); then compound 2.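

In this assay, for the compounds shown here, the first measured change at the pyridyl group, pyridin-4-yl in place of pyridin-3-yl with the 2-chlorophenyl group kept, gives a number 9 percentage points higher from compound 1 to compound 3 (within the scatter) as its step. Within this background, the two pyridyl isomers are therefore not separated by the read-out, although they differ in where the ring nitrogen sits. Compound 1 and compound 3 thus form a pair with the same atoms whose numbers cannot be ordered.

On these data alone, it remains open whether the same swap would also leave the read-out unchanged with the 3-chlorophenyl group of compound 2. Also open, as far as these compounds go, is how pyridin-2-yl, or a phenyl ring bearing an amine or a carboxylic acid, would read at this position. No data at hand bear on the reason for this result.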